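The source may report more compounds than this note shows. Statements on the series, on what has been measured and on what is new or still open speak of the compounds shown alone.

Compound 1, `NCc1ccc(C(=O)Nc2ccncc2F)cc1-c1cccc(C(=O)Oc2ccccc2)c1`: 6.2 nM. Compound 2, `CCCCOC(=O)c1cccc(-c2cc(C(=O)Nc3ccncc3)ccc2CN)c1`: 5.5 nM.

Both were tested in an assay on isolated protein for inhibition of Rho-associated protein kinase 2 (Homo sapiens), read by radiometric assay; a lower number here means a stronger inhibitor, a higher number a weaker inhibitor. Compound 2 gives the lowest number of the two, but compound 1 sits within the scatter of it, so the two show no real difference. Compound 3, `CCCOC(=O)c1cccc(-c2cc(C(=O)Nc3ccncc3)ccc2CN)c1`, is not yet measured. It differs from compound 2 in one place: hydrogen in place of methyl on a saturated chain carbon, three bonds along the chain from an oxygen next to a carbonyl group. Among the measured compounds shown here, no measured pair carries this change, so the expected step is small, with no direction beyond the scatter. Compound 3 is therefore estimated at 6 nM, with a range of 2.5 nM to 15 nM, meaning an expected step of a 1.1-fold higher number from compound 2 to compound 3 (0.04 log units; within the scatter).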

Compound 3, half-maximal inhibitory concentration: 1.4 nM
For compound 3 the middle estimate is 4.3-fold (0.63 log units) above the measured one, outside the stated range (below it).
By their numbers in this assay, from the lowest: compound 3; then compounds 2 and 1 (each within the scatter of the next).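

Going from butyl to propyl on this chain gives a 3.9-fold lower number from compound 2 to compound 3 (0.59 log units; beyond the scatter) in this assay, so this end of the chain is not neutral and the loss of a single carbon can move the number beyond the scatter. It is one pair only, and nothing shown gives a reason for the step. The compounds shown leave open whether an ethyl or methyl group in place of propyl would lower the number further. They also leave open how a carboxylic acid or an amine at this end of the molecule would read.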